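A few compounds are considered here, and "the series" means these few. Any claim that something is new, unique, unknown or untested is made for them only; others in the source may bear on it.

The measured compounds:
compound 1 `COc1cc(-c2nn(-c3cccc(NC(=O)Nc4cc(C(F)(F)F)cc(C(F)(F)F)c4)c3)cc2-c2ccncc2)ccc1Cl`, 250 nM;
compound 2 `COc1cc(-c2nn(-c3cccc(NC(=O)Nc4ccc(Cl)c(Cl)c4)c3)cc2-c2ccncc2)ccc1Cl`, 554 nM;
compound 3 `O=C(Nc1cccc(-n2cc(-c3ccncc3)c(-c3ccc(Cl)c(O)c3)n2)c1)Nc1ccc(Cl)c(Cl)c1`, 834 nM.

All three were tested in a functional assay on PC-3 cells (Homo sapiens) for inhibition, read by sulforhodamine B assay, with a stated time of 48 h; on this read-out lower numbers stand for stronger inhibition of growth and higher numbers for weaker inhibition of growth. Compound 2 holds the second highest of the three numbers. Its nearest neighbour is compound 3, reached by a 1.5-fold higher number from compound 2 to compound 3 (0.18 log units; within the scatter), and the gap to compound 1 lies beyond the usual scatter, compound 1 giving 250 nM against compound 2 with 554 nM.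

Compound 4 `COc1cc(-c2nn(-c3cccc(NC(=O)Nc4ccc(Cl)c(C(F)(F)F)c4)c3)cc2-c2ccncc2)ccc1Cl` has not yet been measured in this assay. It differs from compound 2 by trifluoromethyl in place of chloro on an aromatic carbon.

Going by the values given here, no measured step bears directly on this exchange. Among the compounds with values here, the single step on record, from compound 2 to compound 3, concerns a different position and lies within the scatter. The only hint comes from the pair compound 1 and compound 2, whose shared core carries different substituents on the urea-linked ring, where compound 1 with two trifluoromethyl groups shows the lower number. Compound 4, with one trifluoromethyl and one chloro group there, is therefore expected to fall between the two, with an estimated 1.4-fold lower number from compound 2 to compound 4 (0.14 log units; within the scatter). The estimate for compound 4 in this assay is 400 nM, within a range from 150 nM to 1000 nM.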

Compound 4, concentration for 50% growth inhibition: 690 nM
Compound 4: the middle estimate sits 1.7-fold (0.24 log units) below what was measured; the measured number falls inside the stated range.
By their numbers in this assay, from the lowest: compound 1; then compounds 2, 4 and 3 (each within the scatter of the next).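

In this assay, going by these compounds alone, turning 3,4-dichlorophenyl into 4-chloro-3-(trifluoromethyl)phenyl gives a 1.2-fold higher number from compound 2 to compound 4 (0.10 log units; within the scatter), and this is the first single-place step recorded on the urea-linked ring. Within the data shown here, it shows that, at this aromatic carbon ortho to a chloro group, trifluoromethyl with its four heavy atoms can replace chloro with its one without a change in growth inhibition that can be told from the usual scatter. Nothing among the available data explains this outcome or says what the two groups contribute at this carbon.

The compounds shown leave open whether a different kind of group on this aromatic carbon, such as an amine, a carboxylic acid or a longer alkyl chain, would move the number beyond the scatter, since chloro and trifluoromethyl are the only two groups compared here in a single-place step. They also leave open whether the same exchange would read the same way on the core of compound 3, which has hydrogen in place of the methyl on the oxygen.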